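The source may hold more compounds than are shown below. What is called first, only, known or untested is meant among the compounds shown, and "the series" means these compounds.

Going by the values given here, in a functional assay (muscle tissue) with Cavia porcellus as the target (a lower number here means that less compound is needed, a higher number that more compound is needed for the effect), compound 3 `COC(=O)C1=C(C)N=C(C)/C(=C(\O)OC)C1c1cccc(C#N)c1` gives 34.7 nM, the lowest number so far, against 110 nM for compound 2 `COC(=O)C1=C(C)N=C(C)/C(=C(\O)OC)C1c1cccc(C)c1` and 191 nM for compound 1 `COC(=O)C1=C(C)N=C(C)/C(=C(\O)OC)C1c1cccc(OC)c1`. Compound 4 `COC(=O)C1=C(C)N=C(C)/C(=C(\O)OC)C1c1c(Cl)cccc1Cl` carries 2,6-dichlorophenyl in place of 3-cyanophenyl on a saturated ring carbon. The measured steps bear on this only indirectly: a 1.7-fold lower number from compound 1 to compound 2 (0.24 log units; within the scatter) stays within the scatter, while a 5.5-fold lower number from compound 1 to compound 3 (0.74 log units; beyond the scatter) and a 3.2-fold lower number from compound 2 to compound 3 (0.50 log units; beyond the scatter) are modest. Among the compounds with values here, each swaps a single group on the aromatic ring, whereas here the whole 3-cyanophenyl group is replaced, and no measured compound carries chlorine. These steps give no direction, so no step beyond the scatter is expected in this assay. The expected step is a 1.2-fold lower number from compound 3 to compound 4 (0.06 log units; within the scatter). The estimated value for compound 4 is 30 nM, with an expected range of 8 nM to 120 nM.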

Compound 4, half-maximal effective concentration: 1.91 nM
Compound 4: the middle estimate sits 16-fold (1.20 log units) above what was measured, outside the stated range (below it).
By their numbers in this assay, from the lowest: compound 4; then compound 3; then compounds 2 and 1 (each within the scatter of the next).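

In this assay, going by these compounds alone, replacing the whole aromatic group on this saturated ring carbon with 2,6-dichlorophenyl gives an 18-fold lower number from compound 3 to compound 4 (1.26 log units; beyond the scatter) and so moves the number much further than any swap of a single group among the earlier compounds. Measured from the other two compounds, the same change gives a 58-fold lower number from compound 2 to compound 4 (1.76 log units; beyond the scatter) and a 100-fold lower number from compound 1 to compound 4 (2.00 log units; beyond the scatter) in this set. Nothing available here explains why the change has so large an effect. Still open, on these data alone, is whether a single chlorine on the aromatic ring would do the same, and what an amine or a carboxylic acid there would do to the number.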